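From an aromatic ring to a 2,4-dioxoimidazolidin-1-yl group

The compounds below may be only part of what the source reports. "The series", "measured", "known", "first", "only" and "open" are said of these compounds alone.

In a functional assay on A2780 cells (Homo sapiens) for inhibition (a higher number here means a weaker inhibitor, a lower number a stronger inhibitor), compound 1 `CC(C(=O)Nc1cc(C2CC2)[nH]n1)c1ccc(N2CCCC2)cc1` gives 370 nM, while compound 2 `CC(C(=O)Nc1cc(C2CC2)[nH]n1)c1ccc(-n2ccnc2O)cc1` gives 6980 nM, the higher of the two numbers and so the weaker inhibitor. Compound 3 `CC(C(=O)Nc1cc(C2CC2)[nH]n1)c1ccc(N2CC(=O)NC2=O)cc1` keeps the shared core and changes one group: a group of 7 heavy atoms (3 carbon, 2 nitrogen, 2 oxygen; one five-membered non-aromatic ring with 2 hetero atoms) in place of a group of 6 heavy atoms (3 carbon, 2 nitrogen, 1 oxygen; one five-membered aromatic ring with 2 hetero atoms), on an aromatic carbon. Among the measured compounds shown here, only one measured step bears on this change. It is a 19-fold higher number from compound 1 to compound 2 (1.28 log units; beyond the scatter), a large step that came with an aromatic ring replacing a non-aromatic one at the same place. Compound 3 returns to a non-aromatic ring, but not the ring of compound 1 at 370 nM, and a single step cannot show how much of that gap would close. A small move towards a lower number in this assay is therefore expected. The expected step is a 1.7-fold lower number from compound 2 to compound 3 (0.24 log units; within the scatter). The estimate for compound 3 is 4000 nM, with an expected range of 900 nM to 15000 nM.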

Compound 3, half-maximal inhibitory concentration: 4540 nM
Compound 3: middle estimate off by 1.1-fold (0.05 log units), on the low side; measured number inside the range.
By their numbers in this assay, from the lowest: compound 1; then compounds 3 and 2 (each within the scatter of the next).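

At this position in this assay the step is a 1.5-fold lower number from compound 2 to compound 3 (0.19 log units; within the scatter) and so the 2,4-dioxoimidazolidin-1-yl group and the aromatic ring it replaces cannot be told apart. The direct comparison with the pyrrolidin-1-yl group is a 12-fold higher number from compound 1 to compound 3 (1.09 log units; beyond the scatter) and this large step shows that a non-aromatic five-membered ring does not by itself bring the number back down. Nothing measured here explains why these groups give such different numbers.

As far as these compounds go, whether the lower number needs the pyrrolidine ring itself remains open, and a piperidin-1-yl ring or a dimethylamino group at this place would test that. With only three groups shown at this one place, it also remains open how far these steps would carry over to a different core.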